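This account rests on a few compounds, and the source may have more. Where it says the series, first, only, none or still open, it means among the compounds named here.

Measured so far:
compound 1 `COCCOCCOCCO[C@@H]1C=CC(=O)[C@@H](CO)O1`: 7900 nM
compound 2 `C#CCO[C@@H]1C=CC(=O)[C@@H](CO)O1`: 9300 nM

In a functional assay on HL-60 cells (Homo sapiens) for inhibition, read by MTT assay, with a stated time of 72 h (a higher number here means a weaker inhibitor, a lower number a stronger inhibitor), compound 1 gives 7900 nM and compound 2 gives 9300 nM; the two numbers sit within the scatter of each other, so compound 2 is not set apart from compound 1 on these data. Compound 3 `CC(C)O[C@@H]1C=CC(=O)[C@@H](CO)O1` is not yet measured. It differs from compound 2 in one place: isopropyl in place of propargyl on an oxygen on a saturated carbon. For the measured compounds named here, no step between measured compounds is known, and the two compounds measured so far give like numbers. The step expected in this assay is a 1.0-fold lower number from compound 2 to compound 3 (0.01 log units; within the scatter), none beyond the scatter. Compound 3 is expected to give 9000 nM, with a range of 4000 nM to 20000 nM.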

Compound 3, half-maximal inhibitory concentration: 9700 nM
The estimate for compound 3 lay 1.1-fold (0.03 log units) below the measured number; the range from low to high includes it.
By their numbers in this assay, from the lowest: compounds 1, 2 and 3 (each within the scatter of the next).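

Isopropyl in place of propargyl on an oxygen on a saturated carbon gives a 1.0-fold higher number from compound 2 to compound 3 (0.02 log units; within the scatter) in this assay and so leaves the number in place. At this position, the triple bond of propargyl is therefore not required to keep the number, at least with isopropyl as the replacement. Nothing available explains this result. On these data alone, whether an amine, a carboxylic acid or a longer alkyl chain on this oxygen would move the number stays open. So does the effect of any change to the shared core.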